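The compounds below may be only part of what the source reports. "The series", "measured", "known", "first", "only" and "open" are said of these compounds alone.

Measured so far in a physicochemical assay for solubility, read by HPLC, with a stated time of 24 h; a higher number here means a more soluble compound, a lower number a less soluble compound:
- compound 1 `O=C1O[C@@H](CN2CCCCC2)CN1c1ccc(-n2cc(-c3ccccn3)cn2)c(F)c1` gives 219000 nM
- compound 2 `O=C1CNC(=O)N1C[C@H]1CN(c2ccc(-n3cc(-c4ccccn4)cn3)c(F)c2)C(=O)O1` gives 1630000 nM
- compound 3 `O=C1O[C@@H](Cn2ccnn2)CN1c1ccc(-n2cc(-c3ccccn3)cn2)c(F)c1` gives 247000 nM

Among these three, compound 1 has the lowest number, although compound 3 sits within the scatter of it, so the two cannot be told apart; only compound 2 stands clearly higher. The step to compound 2 was a 7.4-fold higher number from compound 1 to compound 2 (0.87 log units; beyond the scatter), while the step to compound 3 was a 1.1-fold higher number from compound 1 to compound 3 (0.05 log units; within the scatter).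

Compound 4 `COC(=O)NC[C@H]1CN(c2ccc(-n3cc(-c4ccccn4)cn3)c(F)c2)C(=O)O1` shares the core of compound 1 and differs from it in one place: (methoxycarbonyl)amino in place of piperidin-1-yl on a saturated chain carbon bound to a saturated ring carbon. Among the compounds with values here, no measured step covers exactly this change. The two steps that start from compound 1 show that swapping the piperidin-1-yl for a group with one hydrogen-bond donor and two hydrogen-bond acceptors gave a modest rise, whereas swapping it for a group with no donor gave no change beyond the scatter. Within the data shown here, the entering (methoxycarbonyl)amino is counted with one hydrogen-bond donor and two hydrogen-bond acceptors, so a step of the same kind as the one to compound 2 seems plausible in this assay, though smaller than that is just as likely.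

The expected step is therefore a 2.1-fold higher number from compound 1 to compound 4 (0.31 log units; beyond the scatter), a modest rise. For compound 4 the estimate in this assay is 450000 nM, with a range from 180000 nM to 1200000 nM.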

Compound 4, solubility: 34100 nM
Compound 4: the middle estimate sits 13-fold (1.12 log units) above what was measured; the measured number lies below the stated range.
By their numbers in this assay, from the lowest: compound 4; then compounds 1 and 3 (each within the scatter of the next); then compound 2.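

In this assay, a change on a saturated chain carbon bound to a saturated ring carbon can push the number down as well as up: replacing piperidin-1-yl with (methoxycarbonyl)amino gives a 6.4-fold lower number from compound 1 to compound 4 (0.81 log units; beyond the scatter), and replacing 1H-1,2,3-triazol-1-yl with it gives a 7.2-fold lower number from compound 3 to compound 4 (0.86 log units; beyond the scatter). The counts of hydrogen-bond donors and acceptors do not settle the outcome here, as (methoxycarbonyl)amino and 2,5-dioxoimidazolidin-1-yl have the same counts, yet the step between them is a 48-fold lower number from compound 2 to compound 4 (1.68 log units; beyond the scatter), and compound 2 and compound 4 fall on opposite sides of compound 1. Nothing measured here accounts for this difference between the two groups.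

The compounds shown leave open whether the low number of compound 4 goes with the hydrogen on the nitrogen of its (methoxycarbonyl)amino group or with the methoxy end, a question that an acetylamino group or a methyl on that nitrogen could help to separate. It also remains open where a free primary amine or a carboxylic acid on this same saturated chain carbon would stand among these four compounds.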